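Compound 3 to compound 4 near the assay limit

The compounds below may be only part of what the source reports. "The series", "measured", "known", "first", "only" and "open" are said of these compounds alone.

- compound 1 `C=CCc1cc(-c2ccccc2)ccc1O` gives > 100000 nM as a limit
- compound 2 `C=CCc1cc(-c2ccc(C(F)(F)F)cc2)ccc1OC` gives 89000 nM as a number
- compound 3 `C=CCc1cc(-c2ccc(OC)cc2)ccc1O` gives > 100000 nM as a limit

In a functional assay on HepG2 cells (Homo sapiens) for antiproliferative activity, read by MTT assay, with a stated time of 24 h (on this read-out lower numbers stand for stronger inhibition and higher numbers for weaker inhibition), compound 3 sits at the limit of > 100000 nM in this assay, at which 2 of the 3 values shown sit, and so has only a limit, not a number. Compound 4 `C=CCc1cc(-c2ccc(C(F)(F)F)cc2)ccc1O` differs from it by trifluoromethyl in place of methoxy on an aromatic carbon, para to a large group. Among the measured compounds shown here, the one measured step, a step that the two limits leave unreadable from compound 1 to compound 3, gives no size to carry over. For the measured compounds named here, compound 2 also carries trifluoromethyl and gives 89000 nM as the only number. The estimated at least 1.2-fold lower number from compound 3 to compound 4 (0.09 log units; that floor lies within the scatter) is expected to be small and toward stronger inhibition, and a result at the limit remains possible. Compound 4 is estimated at 80000 nM, with an expected range from 35000 nM to 150000 nM in this assay.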

Compound 4, half-maximal inhibitory concentration: 60300 nM
Compound 4: middle estimate off by 1.3-fold (0.12 log units), on the high side; low and high end bracket the measured number.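

In this assay, among the compounds shown here, trifluoromethyl on an aromatic carbon, para to a large group, gives the first step with a readable floor at this position: in place of methoxy it gives an at least 1.6-fold lower number from compound 3 to compound 4 (0.21 log units; that floor lies within the scatter), and in place of hydrogen it gives an at least 1.6-fold lower number from compound 1 to compound 4 (0.21 log units; that floor lies within the scatter). Hydrogen in place of methyl on an oxygen on an aromatic ring gives a 1.5-fold lower number from compound 2 to compound 4 (0.17 log units; within the scatter), the first comparison between two actual numbers. The first two steps are floors only, and neither floor clears the scatter: the limit of > 100000 nM in this assay, at which 2 of the 4 values shown sit.

The compounds shown leave open how an amine or a carboxylic acid would read on this aromatic carbon. From the compounds shown here alone, whether any group here gives a step beyond the scatter also remains open.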